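Urea series on the shared core: compound 1 to compound 4

The source may report more compounds than this note shows. Statements on the series, on what has been measured and on what is new or still open speak of the compounds shown alone.

Working notes on three measured ureas and amides sharing one core, read in a functional assay on Malme-3M cells (Homo sapiens) for inhibition, read by sulforhodamine B assay, with a stated time of 48 h; on this read-out higher numbers stand for lower toxicity in this test and lower numbers for higher toxicity in this test. Compound 1 `O=C(Nc1cccc(-n2cc(-c3ccncc3)c(-c3ccc(Cl)c(O)c3)n2)c1)Nc1cccc(C(F)(F)F)c1` carries a 3-(trifluoromethyl)phenyl on the urea nitrogen. In this assay compound 1 reaches only a limit, > 32500 nM, as recorded in the limit of > 32500 nM in this assay, at which 1 of the 3 values shown sits. Compound 2 `COc1cc(-c2nn(-c3cccc(NC(=O)Nc4cc(C(F)(F)F)cc(C(F)(F)F)c4)c3)cc2-c2ccncc2)ccc1Cl`, with a bis(trifluoromethyl) urea partner and a methoxy on the chlorophenyl, gives a measured number, 7680 nM. Compound 3 `COc1cc(-c2nn(-c3cccc(NC(=O)c4cccc(C(F)(F)F)c4)c3)cc2-c2ccncc2)ccc1Cl`, the plain amide analogue, again sits at a limit, > 50000 nM, as recorded in the limit of > 50000 nM in this assay, at which 1 of the 3 values shown sits. Compound 1 thus stands among the least toxic members shown, with no number below the cut-off.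

Compound 4 `O=C(Nc1cccc(-n2cc(-c3ccncc3)c(-c3ccc(Cl)c(O)c3)n2)c1)Nc1ccc(Cl)c(Cl)c1` is the unmeasured partner of compound 1, differing by 3,4-dichlorophenyl in place of 3-(trifluoromethyl)phenyl on an amide-type nitrogen. For the measured compounds named here, no measured pair isolates this change, so the step is expected to be small, in either direction, and not beyond the scatter. Compound 4 is therefore expected to remain at or near the limit, with an estimate of 40000 nM (range 15000 nM to 100000 nM), meaning a step that the limit leaves unreadable from compound 1 to compound 4 from compound 1 to compound 4.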

Compound 4, concentration lethal to 50% of the cells: > 32500 nM
Compound 4: only a limit was reported; the forecaster's own chance of this, stated with the estimate: 70%; the middle value lies beyond the limit too.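

Compound 1 and compound 4 both rest at a limit, so no step can be read for 3,4-dichlorophenyl in place of 3-(trifluoromethyl)phenyl on an amide-type nitrogen: the limit of > 32500 nM in this assay, at which 2 of the 4 values shown sit.

The compounds shown leave open how far either compound lies beyond that limit, and whether this change alters toxicity in this test at all.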